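Aryl swap on the shared core: working notes

This account rests on a few compounds, and the source may have more. Where it says the series, first, only, none or still open, it means among the compounds named here.

Measured compounds:
compound 1, `COc1ccccc1-c1cn(C[C@H](O)[C@H]2OC(=O)C(OCc3ccccc3)=C2OCc2ccccc2)nn1` — in a functional assay on HCT-116 cells (Homo sapiens) for antiproliferative activity, read by MTT assay, with a stated time of 72 h (a lower number here means a stronger inhibitor, a higher number a weaker inhibitor), compound 1 gives > 100000 nM, which is a limit of the assay and not a number.
compound 2, `COc1ccccc1-c1cn(C/C=C2\OC(=O)C(OCc3ccccc3)=C2OCc2ccccc2)nn1` — in this assay compound 2 gives > 100000 nM, likewise a limit.

Compound 1 thus stands on a limit only. Among the measured compounds shown here, the one further value shown is also a limit, as the limit of > 100000 nM in this assay, at which 2 of the 2 values shown sit, records. For the measured compounds named here, no measured pair differs in a single place, so no step size can be read from these two compounds.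

Compound 3, `O=C1O[C@H]([C@@H](O)Cn2cc(-c3cc(F)cc(F)c3)nn2)C(OCc2ccccc2)=C1OCc1ccccc1`, differs from compound 1 by 3,5-difluorophenyl in place of 2-methoxyphenyl on an aromatic carbon. With no measured step to rest on, and both shown values sitting at the limit, no shift beyond the scatter is expected in this assay; the most likely outcome is that compound 3 also returns only a limit. Compound 3 is expected at 100000 nM, with a range of 30000 nM to 300000 nM. The expected step is a number no higher from compound 1 to compound 3 (the limit leaves the size open), essentially none.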

Compound 3, half-maximal inhibitory concentration: 48200 nM
Beside the measured number, compound 3's estimate is 2.1-fold (0.32 log units) above it; the range from low to high includes it.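

Among the compounds shown here, of the values shown, only the one for compound 3 is a number: in this assay compound 3 gives 48200 nM. For compound 1, the reading of > 100000 nM is a limit of the assay and not a number. Placing 3,5-difluorophenyl in place of 2-methoxyphenyl on this aromatic carbon of the five-membered aromatic ring with 3 nitrogen brings an at least 2.0-fold lower number from compound 1 to compound 3 (0.31 log units; beyond the scatter), so the read-out does respond to a change of aryl group at this position.

On these data alone, the full size of the step stays open, and the series still rests largely on a single limit: the limit of > 100000 nM in this assay, at which 2 of the 3 values shown sit. Also open, as far as these compounds go, is how a plain phenyl, an aminophenyl or a carboxyphenyl group would read at this position, and whether 3,5-difluorophenyl would give a number on the core of compound 2.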